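The source may report more compounds than this note shows. Statements on the series, on what has been measured and on what is new or still open speak of the compounds shown alone.

Compound 3 `COc1cc(-c2nn(-c3cccc(NC(=O)Nc4ccc(Cl)c(Cl)c4)c3)cc2-c2ccncc2)ccc1Cl` gives 1000 nM in a functional assay on ACHN cells (Homo sapiens) for inhibition, read by sulforhodamine B assay, with a stated time of 48 h (a higher number here means a weaker inhibitor of growth, a lower number a stronger inhibitor of growth), the lowest of the three numbers shown, although compound 1 `O=C(Nc1cccc(-n2cc(-c3ccncc3)c(-c3ccc(Cl)c(O)c3)n2)c1)Nc1cccc(C(F)(F)F)c1` at 1290 nM and compound 2 `COc1cc(-c2nn(-c3cccc(NC(=O)c4cccc(C(F)(F)F)c4)c3)cc2-c2ccncc2)ccc1Cl` at 1890 nM both lie within the scatter of it. Going by the values given here, the single one-point step measured so far, a 1.9-fold lower number from compound 2 to compound 3 (0.28 log units; within the scatter), was small. Compound 4 `O=C(Nc1cccc(-n2cc(-c3ccncc3)c(-c3ccc(Cl)c(O)c3)n2)c1)Nc1ccc(Cl)c(Cl)c1` carries the change (hydrogen in place of methyl on an oxygen on an aromatic ring), on an oxygen on an aromatic ring whose other neighbours are aromatic carbon. Among the compounds with values here, no measured step isolates this change; compound 1, which already carries the hydroxy group with a different urea partner, and compound 3 differ only within the scatter. The expected step in this assay is therefore no change at the digits printed from compound 3 to compound 4 (within the scatter), nothing beyond the scatter. Compound 4 is estimated at 1000 nM, with a range of 450 nM to 2300 nM.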

Compound 4, concentration for 50% growth inhibition: 1040 nM
Beside the measured number, compound 4's estimate is 1.0-fold (0.02 log units) below it; low and high end bracket the measured number.
By their numbers in this assay, from the lowest: compounds 3, 4, 1 and 2 (each within the scatter of the next).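

In this assay, the methoxy to hydroxy change on the 4-chloro-3-methoxyphenyl group can now be read directly (a 1.0-fold higher number from compound 3 to compound 4 (0.02 log units; within the scatter)), and the two groups are not told apart at this oxygen. With the hydroxy group in place, 3,4-dichlorophenyl and 3-(trifluoromethyl)phenyl on the amide-type nitrogen are likewise not told apart (a 1.2-fold lower number from compound 1 to compound 4 (0.09 log units; within the scatter)). No evidence bears on the reason for either result.

On these data alone, whether an amine or a carboxylic acid at this place would move the number remains open. No step shown so far leaves the scatter.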